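Cytotoxicity Outlook for the Methyl Analogue

The source may report more compounds than this note shows. Statements on the series, on what has been measured and on what is new or still open speak of the compounds shown alone.

Three measured compounds share one core and differ only in a single group on an aromatic carbon. Compound 1 `O=C(NC(=S)N1CCc2c(OCCCCCOc3ccc(Cl)cc3)cccc21)c1ccc(F)cc1` gives 31100 nM in an ADME assay on Huh-7 cells (Homo sapiens) for cytotoxicity; a higher number here means that more compound is tolerated, a lower number that less compound is tolerated. Compound 2 `O=C(NC(=S)N1CCc2c(OCCCCCOc3ccc(Cl)cc3)cccc21)c1ccc(Br)cc1` gives 29100 nM in this assay, and compound 3 `O=C(NC(=S)N1CCc2c(OCCCCCOc3ccc(Cl)cc3)cccc21)c1ccc(C(F)(F)F)cc1` gives 32700 nM. Compound 3 holds the highest of the three numbers, but its nearest neighbour compound 1 and its furthest neighbour compound 2 both sit within the scatter of it: a 1.1-fold higher number from compound 1 to compound 3 (0.02 log units; within the scatter) and a 1.1-fold higher number from compound 2 to compound 3 (0.05 log units; within the scatter). Likewise a 1.1-fold lower number from compound 1 to compound 2 (0.03 log units; within the scatter). Compound 4 `Cc1ccc(C(=O)NC(=S)N2CCc3c(OCCCCCOc4ccc(Cl)cc4)cccc32)cc1` is not yet measured in this assay; it differs from compound 3 by methyl in place of trifluoromethyl on an aromatic carbon. All three measured steps exchange one group at the same place, and none of them moved the number beyond the scatter, so the change to compound 4 is expected to behave the same way. The expected step is therefore a 1.1-fold lower number from compound 3 to compound 4 (0.02 log units; within the scatter), none beyond the scatter in either direction. Compound 4 is estimated at 31000 nM in this assay, with a range from 15000 nM to 62000 nM.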

Compound 4, half-maximal cytotoxic concentration: > 50000 nM
Compound 4: no number, only a limit (the forecaster's own chance of this, stated with the estimate: 10%); middle value at least 1.6-fold (0.20 log units) away from the limit.
By their numbers in this assay, from the lowest: compounds 2, 1 and 3 (each within the scatter of the next). At a limit, above all of these: compound 4.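

In this assay compound 4 carries no number, only a limit of the assay: the limit of > 50000 nM in this assay, at which 1 of the 4 values shown sits. The steps to it give floors only, an at least 1.5-fold higher number from compound 3 to compound 4 (0.18 log units; that floor lies within the scatter), an at least 1.7-fold higher number from compound 2 to compound 4 (0.23 log units; that floor lies within the scatter) and an at least 1.6-fold higher number from compound 1 to compound 4 (0.20 log units; that floor lies within the scatter), so methyl is the only group shown at this position that reaches the limit, yet each floor still lies within the scatter and no real separation from trifluoromethyl, bromo or fluoro is established. Compound 1, compound 2 and compound 3 showed no movement beyond the scatter among themselves, and compound 4 shows that this flat reading cannot yet be extended to methyl.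

From the compounds shown here alone, how far past its limit compound 4 lies remains open. Also open, going by these compounds, is whether an amine, a carboxylic acid or a longer chain at this position would read like methyl or like the other three groups.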